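The source may hold more compounds than are shown below. What is called first, only, known or untested is meant among the compounds shown, and "the series" means these compounds.

Measured so far in an ADME assay (liver) for metabolic stability, with Liver microsome (Rattus norvegicus) as the target, using microsomes and NADPH, with a stated time of 30 min, tested at 1 uM; on this read-out higher numbers stand for fast clearance and lower numbers for slow clearance:
- compound 1 `Nc1ccc(S(=O)(=O)N2CCN(c3ncc(C(O)(C(F)(F)F)C(F)(F)F)cc3C#CCCO)CC2)cn1` gives 68 mL.min-1.g-1
- compound 2 `CC(C)(C)n1cc(-c2cc(C(O)(C(F)(F)F)C(F)(F)F)cnc2N2CCN(S(=O)(=O)c3ccc(N)nc3)CC2)cn1` gives 459 mL.min-1.g-1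

Of these two numbers, the higher belongs to compound 2, at 459 mL.min-1.g-1. Compound 3 `Cc1csc(-c2cc(C(O)(C(F)(F)F)C(F)(F)F)cnc2N2CCN(S(=O)(=O)c3ccc(N)nc3)CC2)c1` carries 4-methylthiophen-2-yl in place of 1-(tert-butyl)-1H-pyrazol-4-yl on an aromatic carbon. For the measured compounds named here, only one measured step bears on this place, a 6.8-fold higher number from compound 1 to compound 2 (0.83 log units; beyond the scatter). That step put 1-(tert-butyl)-1H-pyrazol-4-yl in place of 4-hydroxybut-1-yn-1-yl, whereas here one five-membered aromatic ring replaces another, so it gives no direct measure for the new change. A smaller shift in this assay is therefore expected, either a slight fall or nothing beyond the scatter. The expected change is a 1.5-fold lower number from compound 2 to compound 3 (0.18 log units; within the scatter). For compound 3 the estimated value is 300 mL.min-1.g-1, within an expected range of 130 mL.min-1.g-1 to 620 mL.min-1.g-1.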

Compound 3, intrinsic clearance in microsomes: 399 mL.min-1.g-1
Compound 3: middle estimate off by 1.3-fold (0.12 log units), on the low side; measured number inside the range.
By their numbers in this assay, from the lowest: compound 1; then compounds 3 and 2 (each within the scatter of the next).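

In this assay, 4-methylthiophen-2-yl in place of 1-(tert-butyl)-1H-pyrazol-4-yl gives a 1.2-fold lower number from compound 2 to compound 3 (0.06 log units; within the scatter) and so leaves the number unmoved beyond the scatter, although the entering ring has fewer heavy atoms and one hetero atom, a sulfur, rather than two nitrogens. The step of a 5.9-fold higher number from compound 1 to compound 3 (0.77 log units; beyond the scatter) shows that the gap to the 4-hydroxybut-1-yn-1-yl group of compound 1 is not confined to the 1-(tert-butyl)-1H-pyrazol-4-yl group, since compound 2 and compound 3 both stand well above compound 1 at this position. Nothing measured here bears on why these numbers fall as they do.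

The compounds shown leave open which part of the 4-hydroxybut-1-yn-1-yl chain, its hydroxyl or its triple bond, goes with the lower number in this assay. They also leave open where a carboxylic acid or a piperidine at this position would fall.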